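This account rests on a few compounds, and the source may have more. Where it says the series, first, only, none or still open, it means among the compounds named here.

Measured in a functional assay on P388 cells (Mus musculus) for antiproliferative activity, read by colorimetric assay and MTT assay; on this read-out lower numbers stand for stronger inhibition and higher numbers for weaker inhibition:
Compound 1 `COc1ccc(S(=O)(=O)Nc2cccc3cc[nH]c23)cc1`: 1.1 ug/mL
Compound 2 `Nc1ccc(S(=O)(=O)Nc2ccc(Cl)c3c(Cl)c[nH]c23)cc1`: 0.49 ug/mL
Compound 3 `Nc1ccc(S(=O)(=O)Nc2ccc(Br)c3c(Cl)c[nH]c23)cc1`: 0.64 ug/mL

The three numbers lie close together. Compound 3, at 0.64 ug/mL, holds the second highest of them, yet it stays within the scatter of both compound 2 and compound 1.

Compound 4 `Nc1ccc(S(=O)(=O)Nc2ccc(-c3ccccc3)c3c(Cl)c[nH]c23)cc1` has phenyl in place of bromo on an aromatic carbon of compound 3: phenyl in place of bromo on an aromatic carbon.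

Among the measured compounds shown here, only one measured step bears on this change. It is the swap of chloro for bromo at the same place, a 1.3-fold higher number from compound 2 to compound 3 (0.12 log units; within the scatter). That step is small and lies within the scatter, but it joins two halogens and says little about a group that brings a ring. For the measured compounds named here, no compound measured so far carries a ring at this place, so the step gives only a weak guide. In this assay a modest rise in the number is therefore expected, with little confidence in its direction, and a step beyond the scatter cannot be ruled out.

The estimated change is a 1.4-fold higher number from compound 3 to compound 4 (0.15 log units; within the scatter).

For compound 4 the expected value is 0.9 ug/mL, with an estimated range from 0.3 ug/mL to 3 ug/mL.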

Compound 4, half-maximal inhibitory concentration: 19 ug/mL
The estimate for compound 4 lay 21-fold (1.32 log units) below the measured number; measured number above the stated range.
By their numbers in this assay, from the lowest: compounds 2, 3 and 1 (each within the scatter of the next, the first and the last beyond it); then compound 4.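

In this assay this place on the shared core turns out not to be indifferent to what it carries. The swap between the two halogens stayed small with a 1.3-fold higher number from compound 2 to compound 3 (0.12 log units; within the scatter) and gave no sign of this, while the phenyl group brings a 30-fold higher number from compound 3 to compound 4 (1.47 log units; beyond the scatter) and likewise a 39-fold higher number from compound 2 to compound 4 (1.59 log units; beyond the scatter) and so marks a large weakening of inhibition against either halogen. Among the compounds shown here, these are the first steps at this place to lie beyond the scatter, and they show that a single halogen atom cannot stand in for a six-membered aromatic ring here, though nothing at hand says what lies behind the loss.

The compounds shown leave open whether an amine, a methyl group or a short alkyl chain at this place would stay close to the two halogens or fall toward phenyl. They also leave open whether a saturated ring such as cyclohexyl would behave as phenyl does, and whether a phenyl ring bearing a carboxylic acid or a methoxy group would regain any of the lost inhibition.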